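Chlorine Placement on the Benzylsulfanyl Arm

A few compounds are considered here, and "the series" means these few. Any claim that something is new, unique, unknown or untested is made for them only; others in the source may bear on it.

Of the compounds shown here, three built on a shared core have been measured in a functional assay on the whole organism (artery, strain albino) with Rattus norvegicus as the target, with a stated time of 900 min, at a dose of 10 mg/kg by the oral route; a higher number here means more inhibition at the dose given (going by the name of the read-out), a lower number less inhibition. Compound 1 `COc1ccc(C2N=C(SCc3cccc(Cl)c3)NC(C)=C2C(=O)Nc2ccc(F)cc2)cc1OC` gives 13.3% in this assay. Compound 2 `COc1ccc(C2N=C(SCc3ccc(Cl)cc3)NC(C)=C2C(=O)Nc2ccc(F)cc2)cc1OC` gives 20% in this assay. Compound 3 `CC1=C(C(=O)Nc2ccc(Br)cc2)C(c2ccc(Cl)cc2Cl)N=C(SCc2cccc(Cl)c2)N1` gives 7.2% in this assay. The change from compound 1 to compound 2 is 4-chlorophenyl in place of 3-chlorophenyl on a saturated chain carbon bound to a sulfur, and the step it made was a number 6.7 percentage points higher from compound 1 to compound 2 (within the scatter). The difference between the core of compound 1 and the core of compound 3 is not broken down here; their two numbers lie within the scatter of each other, whereas the number for compound 2 lies beyond the scatter above that of compound 3.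

Compound 4 `CC1=C(C(=O)Nc2ccc(Br)cc2)C(c2ccc(Cl)cc2Cl)N=C(SCc2ccc(Cl)cc2)N1` has not yet been measured in this assay. It differs from compound 3 by 4-chlorophenyl in place of 3-chlorophenyl on a saturated chain carbon bound to a sulfur, the same change that separated compound 1 from compound 2, at the same place. Within the data shown here, the one observed instance of this change, a number 6.7 percentage points higher from compound 1 to compound 2 (within the scatter), was within the scatter, so compound 4 is expected to sit close to compound 3. Among the measured compounds shown here, on that basis the estimated step from compound 3 to compound 4 is a number 5.8 percentage points higher from compound 3 to compound 4 (within the scatter), a rise of about the size seen before, because the only precedent is a number 6.7 percentage points higher from compound 1 to compound 2 (within the scatter). Compound 4 is therefore expected to give about 13% in this assay, with a plausible range from 3% to 25%.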

Compound 4, a percentage reported as inhibition, in the whole organism at one dose (the size of the read-out at that dose, not a potency): 22.1%
Estimate against measurement, compound 4: 9.1 percentage points below, within the range that was stated.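

On the core of compound 3, 4-chlorophenyl in place of 3-chlorophenyl on a saturated chain carbon bound to a sulfur gave a number 14.9 percentage points higher from compound 3 to compound 4 (beyond the scatter) in this assay. Set beside the earlier step, this one does not differ from it by more than two such steps can scatter, so the two cores give no sign of treating the change differently: the same change on two cores in this assay, a number 6.7 percentage points higher (within the scatter) from compound 1 to compound 2 and a number 14.9 percentage points higher (beyond the scatter) from compound 3 to compound 4, 8.2 percentage points apart, within the scatter of two such steps This does not show that the step is larger on one core than on the other, and two pairs cannot show that it would hold on any further core; only one of the two steps lies beyond the scatter, and each number is a reading at a single dose rather than a potency.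

The benzyl arm in the compounds shown always carries one chlorine, so it remains open how 2-chlorobenzyl, an unsubstituted benzyl, or a benzyl bearing an amine or a carboxylic acid would read on either core. Also open, as far as these compounds go, is whether a longer chain on the sulfur would leave the step intact, and whether the two cores would still agree at another dose.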